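Swapping the Bicyclic Amide for 4,4-Difluorocyclohexyl

The source may hold more compounds than are shown below. What is called first, only, known or untested is meant among the compounds shown, and "the series" means these compounds.

Measured compounds:
Compound 1, `CC(C)N(C(=O)[C@H]1CC[C@@H]2C[C@@H]2CC1)c1cc(C#CC(C)(C)C)sc1C(=O)O`: 0.08
Compound 2, `CC(C)N(C(=O)C1CCCCCC1)c1cc(C#CC(C)(C)C)sc1C(=O)O`: 0.11
Compound 3, `CC(C)N(C(=O)[C@@H]1CC[C@@H]2C[C@@H]2CC1)c1cc(C#CC(C)(C)C)sc1C(=O)O`: 0.05

In an ADME assay for protein binding, using equilibrium dialysis, at pH 7.4, tested at 2 uM (a higher number here means a larger unbound share of the compound, a lower number a smaller unbound share), compound 3 gives the lowest of the three numbers. Its nearest neighbour is compound 1, with a 1.6-fold lower number from compound 1 to compound 3 (0.20 log units; within the scatter); the two compounds differ only in configuration as drawn (the fact that compounds 1 and 3 differ only in the configuration as drawn). The step of a 2.2-fold lower number from compound 2 to compound 3 (0.34 log units; beyond the scatter) is larger, and the companion step a 1.4-fold higher number from compound 1 to compound 2 (0.14 log units; within the scatter) is small.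

Compound 4, `CC(C)N(C(=O)C1CCC(F)(F)CC1)c1cc(C#CC(C)(C)C)sc1C(=O)O`, is not yet measured in this assay. It differs from compound 3 at the carbonyl carbon: a group of 8 heavy atoms (6 carbon, 2 fluorine; one six-membered non-aromatic ring of carbon only) in place of a group of 8 heavy atoms (8 carbon; one three-membered non-aromatic ring of carbon only, one seven-membered non-aromatic ring of carbon only), on a carbonyl carbon. The measured steps at this same carbonyl carbon, a 1.4-fold higher number from compound 1 to compound 2 (0.14 log units; within the scatter) and a 2.2-fold lower number from compound 2 to compound 3 (0.34 log units; beyond the scatter), show that changing the ring attached there moves the unbound fraction by at most a modest amount. Since the ring entering in compound 4 is again a change at this position, a modest step upward is expected, estimated as a 2.0-fold higher number from compound 3 to compound 4 (0.30 log units; within the scatter). For compound 4 the expected value in this assay is 0.1, with a range from 0.05 to 0.22.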

Compound 4, unbound fraction: 0.4
Compound 4: middle estimate off by 4.0-fold (0.60 log units), on the low side; measured number outside the range, above it.
By their numbers in this assay, from the lowest: compounds 3, 1 and 2 (each within the scatter of the next, the first and the last beyond it); then compound 4.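

In this assay the carbonyl carbon proves able to carry far larger changes than the earlier rings suggested, for 4,4-difluorocyclohexyl lifts the unbound fraction above all three all-carbon rings (an 8.0-fold higher number from compound 3 to compound 4 (0.90 log units; beyond the scatter)) (a 5.0-fold higher number from compound 1 to compound 4 (0.70 log units; beyond the scatter)) (a 3.6-fold higher number from compound 2 to compound 4 (0.56 log units; beyond the scatter)). Among the earlier compounds the only step at this place beyond the scatter was the smaller one (a 2.2-fold lower number from compound 2 to compound 3 (0.34 log units; beyond the scatter)), so the ring entering in compound 4 sets it apart from compound 1, compound 2 and compound 3 alike. Nothing given here explains this rise.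

Going by these compounds, whether the rise follows the two fluorine atoms or the six-membered ring stays open, as both enter together in compound 4. Plain cyclohexyl, which carries no fluorine, would separate the two.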